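The source may report more compounds than this note shows. Statements on the series, on what has been measured and on what is new or still open speak of the compounds shown alone.

Compound 1 `O=C(Nc1ccccn1)c1cccc(Oc2ccc3c(c2)c(=O)ncn3Cc2c(F)cc(F)cc2F)c1C(F)(F)F` gives 1.2 10^-6 cm/s in an ADME assay on Caco-2 cells (Homo sapiens) for permeability, in the apical to basolateral direction (on this read-out higher numbers stand for higher permeability and lower numbers for lower permeability), the lowest of the two numbers measured here. For the measured compounds named here, compound 2 `O=c1ncn(Cc2c(F)cc(F)cc2F)c2ccc(Oc3cccc(-c4ccc5[nH]ccc5c4)c3C(F)(F)F)cc12` gives 10.5 10^-6 cm/s in this assay; the single change between them brought an 8.8-fold higher number from compound 1 to compound 2 (0.94 log units; beyond the scatter), a modest rise that lies beyond the scatter. Compound 3 `Nc1ccc(-c2cccc(Oc3ccc4c(c3)c(=O)ncn4Cc3c(F)cc(F)cc3F)c2C(F)(F)F)cn1` carries a related change: 6-aminopyridin-3-yl in place of (pyridin-2-yl)carbamoyl on an aromatic carbon. Going by the values given here, only the step from compound 1 to compound 2 bears on this, and it points upward, so a rise beyond the scatter is expected, though a smaller one is estimated, namely a 4.2-fold higher number from compound 1 to compound 3 (0.62 log units; beyond the scatter). Compound 3 is therefore estimated at 5 10^-6 cm/s, within a range from 2 10^-6 cm/s to 12 10^-6 cm/s.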

Compound 3, apparent permeability: 4.1 10^-6 cm/s
Compound 3: middle estimate off by 1.2-fold (0.09 log units), on the high side, within the range that was stated.
By their numbers in this assay, from the lowest: compound 1; then compound 3; then compound 2.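

6-aminopyridin-3-yl in place of (pyridin-2-yl)carbamoyl brings a 3.4-fold higher number from compound 1 to compound 3 (0.53 log units; beyond the scatter) in this assay at this position, so the rise does not belong to 1H-indol-5-yl alone. The two replacements are not equal, since 6-aminopyridin-3-yl in place of 1H-indol-5-yl gives a 2.6-fold lower number from compound 2 to compound 3 (0.41 log units; beyond the scatter) and leaves the number between the other two. The leaving and entering groups have the same counts of hydrogen-bond donors and acceptors, so those counts alone do not follow this rise.

As far as these compounds go, whether a group without a ring, such as a simple amine or a carboxylic acid, would fit this trend remains open. No measured evidence here explains these differences.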